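Three Limits and a Fourth Ketone Analogue

A few compounds are considered here, and "the series" means these few. Any claim that something is new, unique, unknown or untested is made for them only; others in the source may bear on it.

Compound 1, `CC(C)[C@H](NC(=O)COc1cccc2ccccc12)C(=O)N[C@@H](CC(=O)O)C(=O)CSc1nc2ccccc2o1`, compound 2, `CC(C)[C@H](NC(=O)COc1cccc2ccccc12)C(=O)N[C@@H](CC(=O)O)C(=O)CSc1nc2ccccc2[nH]1`, and compound 3, `CC(C)[C@H](NC(=O)COc1cccc2ccccc12)C(=O)N[C@@H](CC(=O)O)C(=O)COn1nnc2ccccc21`, share one core and differ only in the aromatic group carried at the end of the ketone side chain. All three were tested in a functional assay on Jurkat cells (Homo sapiens) for inhibition; on this read-out higher numbers stand for weaker inhibition and lower numbers for stronger inhibition. In this assay compound 1 gives > 200000 nM, which is a limit of the assay rather than a number. Compound 2 likewise gives > 200000 nM, again a limit. Compound 3 stands at > 200000 nM, also a limit, so its position relative to the other two cannot be read. The steps among them are accordingly unreadable: a step that the two limits leave unreadable from compound 1 to compound 2, a step that the two limits leave unreadable from compound 1 to compound 3 and a step that the two limits leave unreadable from compound 2 to compound 3. Together this is the limit of > 200000 nM in this assay, at which 3 of the 3 values shown sit.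

Compound 4, `CC(C)[C@H](NC(=O)COc1cccc2ccccc12)C(=O)N[C@@H](CC(=O)O)C(=O)COc1cc2ccccc2cn1`, is the next member of the series. It differs from compound 3 in one place: a group of 10 heavy atoms (9 carbon, 1 nitrogen; one six-membered aromatic ring of carbon only, one six-membered aromatic ring with 1 hetero atom) in place of a group of 9 heavy atoms (6 carbon, 3 nitrogen; one five-membered aromatic ring with 3 hetero atoms, one six-membered aromatic ring of carbon only), on an oxygen on a saturated carbon. Going by the values given here, no measured step bears on this change in a readable way, since every step sits between two limits. The expectation for compound 4 therefore rests only on the three limits. The expected step is a number no higher from compound 3 to compound 4 (the limit leaves the size open), which is to say none beyond the scatter in either direction. Compound 4 is thus expected to give about 200000 nM in this assay, within 50000 nM to 600000 nM, with a high chance that only a limit is again reported.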

Compound 4, half-maximal inhibitory concentration: > 200000 nM
Compound 4: a limit, no number; the forecaster's own chance of this, stated with the estimate: 75%; the middle value sits exactly at the limit.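

In this assay, going by these compounds alone, compound 4 gives > 200000 nM, a limit and not a number, so no step from compound 1, compound 2 or compound 3 to compound 4 can be read. All the values now stand together: the limit of > 200000 nM in this assay, at which 4 of the 4 values shown sit. The compounds shown leave open how the isoquinolin-3-yl group and the other aromatic end groups rank against one another.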